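Dropping One Trifluoromethyl From a Bis-Trifluoromethyl Urea

A few compounds are considered here, and "the series" means these few. Any claim that something is new, unique, unknown or untested is made for them only; others in the source may bear on it.

Measured so far:
- compound 1 `O=C(Nc1cccc(-n2cc(-c3ccncc3)c(-c3cc(O)cc(Cl)c3)n2)c1)Nc1ccc(Cl)c(C(F)(F)F)c1`: -9%
- compound 2 `O=C(Nc1cccc(-n2cc(-c3ccncc3)c(-c3cc(O)cc(Cl)c3)n2)c1)Nc1ccc(Cl)c(Cl)c1`: 5%
- compound 3 `COc1cc(Cl)cc(-c2nn(-c3cccc(NC(=O)Nc4cc(C(F)(F)F)cc(C(F)(F)F)c4)c3)cc2-c2ccncc2)c1`: -42%

All three share a urea-linked core and were tested in a functional assay on K562 cells (Homo sapiens) for inhibition, read by sulforhodamine B assay, with a stated time of 48 h, tested at 100 uM; a higher number here means a weaker effect of the compound at the concentration tested, a lower number a stronger effect. Compound 3 gives the lowest number of the three; compound 1 stands nearest to it, and compound 2 furthest. For the measured compounds named here, compound 3 also carries a methoxy where compounds 1 and 2 carry a hydroxy, so no single step joins it to either of them, and their values can only be set side by side.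

Compound 4 `COc1cc(Cl)cc(-c2nn(-c3cccc(NC(=O)Nc4cccc(C(F)(F)F)c4)c3)cc2-c2ccncc2)c1` is compound 3 with one change: hydrogen in place of trifluoromethyl on an aromatic carbon. Going by the values given here, the only measured step that touches a trifluoromethyl on the urea aryl is a number 14 percentage points higher from compound 1 to compound 2 (beyond the scatter), where chloro took the place of trifluoromethyl and the number rose modestly. Hydrogen in place of trifluoromethyl is a different swap, so that step bears only loosely on this one. A modest rise in this assay is expected, a number 20 percentage points higher from compound 3 to compound 4 (beyond the scatter). Compound 4 is estimated at -22%, within a range from -48% to 8%.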

Compound 4, a percentage reported as activity, at one concentration (the size of the read-out at that concentration, not a potency): -22%
Compound 4: the middle estimate sits on the measured number at the digits printed; low and high end bracket the measured number.
By their numbers in this assay, from the lowest: compound 3; then compound 4; then compound 1; then compound 2.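

In this assay, trading one trifluoromethyl for plain hydrogen gives a number 20 percentage points higher from compound 3 to compound 4 (beyond the scatter), which shows that this position matters even when nothing takes the group's place. Compound 4, with one trifluoromethyl left on the six-membered aromatic ring, still gives -22%, so losing this group weakens the effect at the tested concentration without bringing the number up to zero. Nothing measured on these compounds accounts for the shift.

The compounds shown leave open whether a methyl group or an amine on the same carbon would move the number as hydrogen does. They also leave open whether removing the remaining trifluoromethyl would raise the number further, and whether this swap would behave the same way with hydroxy in place of methoxy.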